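Working notes: from compound 3 to compound 4

The source may report more compounds than this note shows. Statements on the series, on what has been measured and on what is new or still open speak of the compounds shown alone.

Of the compounds shown here, three of the shared core have been measured in an assay on isolated protein with Bile acid receptor (Homo sapiens) as the target; on this read-out lower numbers stand for an effect already at smaller amounts and higher numbers for an effect only at larger amounts of compound. Compound 1 `COC(=O)/C=C/c1cccc(N(Cc2ccc(/C=C/c3cc(C(F)(F)F)cc(C(F)(F)F)c3)cc2)C(=O)C2CCCCC2)c1` gives 1470 nM. Compound 2 `COC(=O)/C=C/c1cccc(N(Cc2ccc(/C=C/c3cccc(C(F)(F)F)c3)cc2)C(=O)NC(C)C)c1` gives 932 nM. Compound 3 `COC(=O)/C=C/c1cccc(N(Cc2ccc(/C=C/c3cccc(F)c3)cc2)C(=O)C(C)C)c1` gives 71 nM, the lowest number of the three; its gap to compound 2, the nearest, lies beyond the scatter, and its gap to compound 1 is larger still. No pair among these three differs in only one place, so no single step can be read from them.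

Compound 4 `COC(=O)/C=C/c1cccc(N(Cc2ccc(-c3ccc(N(C)C)cc3)cc2)C(=O)C(C)C)c1` has not yet been measured. It differs from compound 3 in one place: 4-(dimethylamino)phenyl in place of 2-(3-fluorophenyl)ethenyl on an aromatic carbon. Going by the values given here, compound 3 is the only measured compound that carries this same acyl group on the nitrogen, so the effect of the change must be estimated without a measured counterpart.

For compound 4 the expected step in this assay from compound 3 is a 4.2-fold higher number from compound 3 to compound 4 (0.63 log units; beyond the scatter), an upward move beyond the scatter, because compound 3 at 71 nM sits well below compounds 1 and 2 and a change of this size at this place is not covered by any measured pair. The estimate for compound 4 is 300 nM, with a range from 70 nM to 1500 nM.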

Compound 4, half-maximal effective concentration: 57 nM
For compound 4 the middle estimate is 5.3-fold (0.72 log units) above the measured one; measured number outside the range, below it.
By their numbers in this assay, from the lowest: compounds 4 and 3 (each within the scatter of the next); then compounds 2 and 1 (each within the scatter of the next).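

In this assay the exchange of 2-(3-fluorophenyl)ethenyl for 4-(dimethylamino)phenyl gives a 1.2-fold lower number from compound 3 to compound 4 (0.10 log units; within the scatter) and so leaves the two compounds indistinguishable on this read-out. With the acyl group on the nitrogen held constant, this place, para to a large group, accepts a substituent without the double bond outside aromatic rings and without fluorine, and one that brings in a nitrogen, with no readable loss in this pair. No measured information is available to explain why these two different groups give matching numbers.

Going by these compounds, the exchange alters the double bond, the fluorine and the dimethylamino nitrogen at once, so the share of each remains open, as does the outcome with a plain phenyl, a morpholine ring or a primary amine at the same place. Also open, on these data alone, is whether the exchange holds with a different acyl group on the nitrogen, such as the cyclohexanecarbonyl group of compound 1, or with a carboxylic acid in place of the methyl ester.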